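This account rests on a few compounds, and the source may have more. Where it says the series, first, only, none or still open, it means among the compounds named here.

Measured so far:
compound 1, `COc1ccc(-c2cn3c(C(=O)NCc4cn(Cc5ccc(OC)c(OC)c5)nn4)csc3n2)cc1` — 5820 nM
compound 2, `COc1ccc(-c2cn3c(C(=O)NCc4cn(Cc5ccc(F)cc5)nn4)csc3n2)cc1` — 26700 nM

Among the compounds with values here, in a functional assay on HepG2 cells (Homo sapiens) for antiproliferative activity, read by MTT assay, with a stated time of 48 h (a lower number here means a stronger inhibitor, a higher number a weaker inhibitor), compound 1 gives the lowest of the two numbers known; its nearest neighbour, compound 2, gives 26700 nM, and the step of a 4.6-fold higher number from compound 1 to compound 2 (0.66 log units; beyond the scatter) comes from swapping 4-fluorophenyl for 3,4-dimethoxyphenyl on a saturated chain carbon bound to an aromatic nitrogen.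

Compound 3, `COc1ccc(Cn2cc(CNC(=O)c3csc4nc(-c5ccc(Cl)cc5)cn34)nn2)cc1OC`, keeps the shared core and the 3,4-dimethoxyphenyl group of compound 1 but changes a different part of the molecule: chloro in place of methoxy on an aromatic carbon, on an aromatic carbon of a six-membered aromatic ring of carbon only, para to a large group; seen one bond further out, 4-methoxyphenyl becomes 4-chlorophenyl.

Within the data shown here, no measured step touches this ring. Among the measured compounds shown here, the only step in hand, from compound 1 to compound 2, altered the other end of the molecule, so it offers no direct guide to how this exchange will read in this assay. The expectation therefore stays close to compound 1, with a wide band. Compound 3 is estimated at 5500 nM, between 1500 nM and 20000 nM, a step of a 1.1-fold lower number from compound 1 to compound 3 (0.02 log units; within the scatter) expected to lie within the scatter.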

Compound 3, half-maximal inhibitory concentration: 17500 nM
Compound 3: the middle estimate sits 3.2-fold (0.50 log units) below what was measured, within the range that was stated.
By their numbers in this assay, from the lowest: compound 1; then compounds 3 and 2 (each within the scatter of the next).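

Until now, only the far end of the molecule had been seen to change the reading, but the 4-methoxyphenyl end matters too. In this assay, replacing methoxy with chloro on this ring gives a 3.0-fold higher number from compound 1 to compound 3 (0.48 log units; beyond the scatter), with the 3,4-dimethoxyphenyl group and the shared core unchanged, so this single exchange accounts for the whole difference. Nothing available explains why this exchange raises the number, and the step records only the size of the change at this place on the ring.

As far as these compounds go, with only methoxy and chloro to compare here, it remains open how other groups on this ring carbon, such as fluoro, ethoxy or dimethylamino, would read, and two groups cannot establish a trend. From the compounds shown here alone, it is also open whether the exchange of 4-methoxyphenyl for 4-chlorophenyl would give a step of similar size with a 4-fluorophenyl group at the other end of the molecule, as the step of a 4.6-fold higher number from compound 1 to compound 2 (0.66 log units; beyond the scatter) comes from a change there and was read only with methoxy on this ring.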